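The source may hold more compounds than are shown below. What is called first, only, known or untested is meant among the compounds shown, and "the series" means these compounds.

Compound 1, `O/N=C(/NCc1cccs1)c1ccc2occc2c1`, gives > 30000 nM in an assay on isolated protein for inhibition of Indoleamine 2,3-dioxygenase 1 (Homo sapiens), read by spectrophotometry (a lower number here means a stronger inhibitor, a higher number a weaker inhibitor), which is a limit of the assay rather than a number.
Compound 2, `O/N=C(/NCc1ccco1)c1ccc2occc2c1`, gives > 30000 nM in this assay, again only a limit.

Compound 2 therefore stands at the limit, with no number of its own. Among the compounds with values here, the one measured step, a step that the two limits leave unreadable from compound 1 to compound 2, is unreadable, since (the limit of > 30000 nM in this assay, at which 2 of the 2 values shown sit). Compound 3, `O/N=C(/NCC1CC1)c1ccc2occc2c1`, differs from compound 2 by cyclopropyl in place of furan-2-yl on a saturated chain carbon bound to an amine nitrogen. Within the data shown here, no measured step bears readably on this change, so no direction can be taken from the data. Compound 3 is expected at 30000 nM, within 8000 nM to 100000 nM. The expected step from compound 2 to compound 3 is a number no higher from compound 2 to compound 3 (the limit leaves the size open), most likely again reported only as a limit.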

Compound 3, half-maximal inhibitory concentration: > 30000 nM
Compound 3 ended at the assay's limit; the forecaster's own chance of this, stated with the estimate: 80%; the middle value lies on the limit itself.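

No new step can be read among compound 1, compound 2 and compound 3, since each result is only a limit: the limit of > 30000 nM in this assay, at which 3 of the 3 values shown sit. The compounds shown leave open whether any group at this place gives a true number in this assay rather than a limit.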